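The compounds below may be only part of what the source reports. "The series", "measured", "known", "first", "only" and "open" are said of these compounds alone.

Measured so far in a functional assay on HEL cells (Homo sapiens); on this read-out lower numbers stand for higher toxicity in this test and higher numbers for lower toxicity in this test:
- compound 1 `O=C1c2ccccc2N(COCc2ccccc2)S(=O)(=O)N1Cc1ccccc1`: 122000 nM
- compound 2 `O=C1c2ccccc2N(Cc2ccccc2Cl)S(=O)(=O)N1Cc1ccccc1`: 200000 nM

Compound 2 `O=C1c2ccccc2N(Cc2ccccc2Cl)S(=O)(=O)N1Cc1ccccc1` gives 200000 nM in this assay. For the measured compounds named here, its only measured neighbour is compound 1, and the step of a 1.6-fold higher number from compound 1 to compound 2 (0.21 log units; within the scatter) is within the scatter, so the two compounds cannot be told apart on this read-out; compound 2 stands with compound 1 rather than apart from it.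

Compound 3 `O=C1c2ccccc2N(Cc2cccc(Cl)c2)S(=O)(=O)N1Cc1ccccc1` has not yet been measured. It differs from compound 2 in one place: 3-chlorophenyl in place of 2-chlorophenyl on a saturated chain carbon bound to a sulfonamide nitrogen in a ring. The same atoms are present in both compounds, only joined differently.

Going by the values given here, no measured step moves a chlorine around the ring in this way, so no step bears directly on this change. Among the compounds with values here, the one step known, from compound 1 to compound 2, exchanged a whole group and still stayed within the scatter, which suggests this read-out is not very sensitive to the group on that carbon. A step within the scatter is therefore expected, with no particular direction, as no change at the digits printed from compound 2 to compound 3 (within the scatter).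

Compound 3 is estimated at 200000 nM, within the range 70000 nM to 500000 nM.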

Compound 3, minimum cytotoxic concentration: > 5000 nM
Compound 3: a limit, no number; the forecaster's own chance of this, stated with the estimate: 25%; the middle value does not contradict the limit.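

In this assay compound 3 gives > 5000 nM, which is a limit and not a number. The steps from compound 1 and from compound 2 to compound 3 therefore cannot be read: the limit of > 5000 nM in this assay, at which 1 of the 3 values shown sits.

The compounds shown leave open whether 3-chlorobenzyl in place of 2-chlorobenzyl changes the toxicity seen in this assay.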